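The compounds below may be only part of what the source reports. "The series", "measured", "known", "first", "only" and "open" are said of these compounds alone.

Measured compounds in an assay on isolated protein for binding affinity to Alpha-1A adrenergic receptor (Rattus norvegicus), read by radioligand binding; a higher number here means a weaker inhibitor, a lower number a stronger inhibitor:

Compound 1 `CCS(=O)(=O)Nc1cccc2c1CCCC2c1c[nH]cn1` gives 46.8 nM.
Compound 2 `CC(=O)Nc1cccc2c1CCCC2c1c[nH]cn1` gives 525 nM.
Compound 3 `COc1ccc2c(c1NS(C)(=O)=O)CCCC2c1c[nH]cn1` gives 501 nM.

Compound 2 gives the highest of the three numbers. Its value and that of compound 3 lie within the scatter of each other, so the two cannot be ordered. Compound 1 stands apart: the step of an 11-fold higher number from compound 1 to compound 2 (1.05 log units; beyond the scatter) is large and beyond the scatter, and it shows that the group on the nitrogen of the shared core carries much of the weight in this assay.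

Compound 4 `O=C(Nc1cccc2c1CCCC2c1c[nH]cn1)C(F)(F)F` keeps the amide of compound 2 and changes only the group on the carbonyl carbon: trifluoromethyl in place of methyl on a carbonyl carbon. For the measured compounds named here, the only measured step that touches this part of the molecule is the one from compound 1 to compound 2, and it replaces the whole acyl group rather than a methyl on an acyl. Nothing measured here tells how a methyl compared with a trifluoromethyl on the carbonyl carbon behaves. The expectation therefore rests on compound 2 alone, with a wide range to either side, and the estimated step of a 1.3-fold lower number from compound 2 to compound 4 (0.12 log units; within the scatter) is taken as not beyond the scatter. For compound 4 the estimate is 400 nM, between 120 nM and 1300 nM.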

Compound 4, inhibition constant: 166 nM
Estimate against measurement, compound 4: 2.4-fold (0.38 log units) above, within the range that was stated.
By their numbers in this assay, from the lowest: compound 1; then compound 4; then compounds 3 and 2 (each within the scatter of the next).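

In this assay, the group on the carbonyl carbon matters on its own: trifluoromethyl in place of methyl gives a 3.2-fold lower number from compound 2 to compound 4 (0.50 log units; beyond the scatter) and so moves the number without any change to the amide itself, which the earlier step, exchanging the whole acyl group, could not show. The amide with trifluoromethyl still does not match the sulfonamide, since the exchange of groups on the nitrogen gives a 3.5-fold higher number from compound 1 to compound 4 (0.55 log units; beyond the scatter) and this step too lies beyond the scatter, so this one change closes only part of the distance seen in an 11-fold higher number from compound 1 to compound 2 (1.05 log units; beyond the scatter) and leaves the ethylsulfonyl compound with the lowest number of the four. Nothing at hand accounts for the effect of trifluoromethyl at this position.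

The compounds shown leave open how a difluoromethyl, an ethyl or a cyclopropyl on the carbonyl carbon would stand, and so whether this single pair marks a trend or an isolated result. They also leave open whether trifluoromethyl in place of the ethyl on the sulfonyl group of compound 1 would move the number the same way.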